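This account rests on a few compounds, and the source may have more. Where it says the series, first, only, none or still open, it means among the compounds named here.

Compound 1 `CC(C)CN(CC(C)C)N1CCN(c2nc(=O)c3cc(C(F)(F)F)cc([N+](=O)[O-])c3s2)CC1` was taken through an ADME assay on Vero cells (Chlorocebus sabaeus) for cytotoxicity, read by MTT assay, with a stated time of 72 h; a higher number here means that more compound is tolerated, a lower number that less compound is tolerated. In this assay compound 1 reaches only the upper limit of the measurement, > 64 ug/mL. Compound 2 `O=c1nc(N2CCN(NCc3ccc(OC(F)(F)F)cc3)CC2)sc2c([N+](=O)[O-])cc(C(F)(F)F)cc12` shares the core of compound 1 and carries a 4-(trifluoromethoxy)benzyl group on the outer nitrogen of the piperazine. In this assay compound 2 likewise gives only a limit, > 64 ug/mL. Compound 2 therefore stands where every value shown so far stands, at the limit of > 64 ug/mL in this assay, at which 2 of the 2 values shown sit, so nothing separates it from compound 1 on these numbers.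

Compound 3 `COc1ccc(CNN2CCN(c3nc(=O)c4cc(C(F)(F)F)cc([N+](=O)[O-])c4s3)CC2)cc1` differs from compound 2 in one place: methyl in place of trifluoromethyl on an oxygen on an aromatic ring. Going by the values given here, no pair of measured compounds differs in a single place, so no measured step guides the expectation. The reasonable expectation is a change from compound 2 to compound 3 of a step that the limit leaves unreadable from compound 2 to compound 3, that is none beyond the scatter. Compound 3 is accordingly expected to give about 70 ug/mL in this assay, in the range 32 ug/mL to 128 ug/mL.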

Compound 3, half-maximal cytotoxic concentration: > 64 ug/mL
Compound 3: a limit, no number (the forecaster's own chance of this, stated with the estimate: 75%); the middle value lies beyond the limit too.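

In this assay compound 3 also gives only a limit, > 64 ug/mL. Going by these compounds alone, no step can therefore be read between compound 3 and compound 1 or compound 2: the limit of > 64 ug/mL in this assay, at which 3 of the 3 values shown sit. The compounds shown leave open whether compound 1, compound 2 and compound 3 differ at all in how much is tolerated.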